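Swapping carboxymethyl for methoxycarbonyl on the shared core

The compounds below may be only part of what the source reports. "The series", "measured", "known", "first", "only" and "open" are said of these compounds alone.

In a functional assay on MCF7 cells (Homo sapiens) for inhibition, read by radiometric assay and XTT assay (on this read-out higher numbers stand for weaker inhibition and lower numbers for stronger inhibition), the measured compounds read as follows.

- Compound 1 `C/C=C/C(C)=C/[C@@]1(C)SC(O)=CC1=O` gives > 80 ug/mL which is a limit of the assay and not a number.
- Compound 2 `CCCC/C=C/C=C/[C@@]1(C)SC(O)=CC1=O` gives 60 ug/mL as a measured number.
- Compound 3 `CCCCCCCC[C@@]1(C)SC(=O)C=C1OCC(=O)O` gives 50.3 ug/mL as a measured number.

Going by the values given here, only two compounds carry true numbers, and compound 3 at 50.3 ug/mL and compound 2 at 60 ug/mL lie within the usual scatter of each other. Compound 3 therefore has one close neighbour and no clear separation from it.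

Compound 4 `CCCCCCCC[C@@]1(C)SC(=O)C=C1OC(=O)OC` has methoxycarbonyl in place of carboxymethyl on an oxygen on an unsaturated carbon and is still to be measured. Among the compounds with values here, no measured pair isolates this change, so any expectation for it is tentative. A small move towards a lower number in this assay is expected, one that may not clear the scatter. The estimated size is a 1.4-fold lower number from compound 3 to compound 4 (0.16 log units; within the scatter) and this remains only an expectation. For compound 4 the estimate is 35 ug/mL with an expected range from 15 ug/mL to 75 ug/mL in this assay.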

Compound 4, half-maximal inhibitory concentration: 21.6 ug/mL
Compound 4: middle estimate off by 1.6-fold (0.21 log units), on the high side; measured number inside the range.
By their numbers in this assay, from the lowest: compound 4; then compounds 3 and 2 (each within the scatter of the next). At a limit, above all of these: compound 1.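

In this assay, a 2.3-fold lower number from compound 3 to compound 4 (0.37 log units; beyond the scatter), and this step lies beyond the scatter. Going by these compounds alone, it is the first comparison in which only one place differs, as no earlier pair isolated a single change, and it shows that the group on this oxygen on an unsaturated carbon can shift the read-out. The two groups hold the same heavy atoms, but methoxycarbonyl has no hydrogen-bond donor where carboxymethyl has one; nothing measured here gives a reason for the step.

As far as these compounds go, it remains open whether an ethoxycarbonyl group or an amide on the same oxygen would read like methoxycarbonyl. From the compounds shown here alone, it is equally open whether a longer chain on the shared core would leave this step unchanged.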